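The source may hold more compounds than are shown below. What is called first, only, known or untested is meant among the compounds shown, and "the series" means these compounds.

The series shares one core, first seen in compound 1 `CCOC(=O)[C@@H]1CC(=O)c2sccc2[C@H]1c1ccc(OC)cc1`, which in a physicochemical assay, read by spectrophotometry, with a stated time of 20 min, tested at 20 ug/mL (a lower number here means a weaker effect, a higher number a stronger effect of the compound at the concentration tested), gives 15%. Among the compounds with values here, compound 2 `CCOC(=O)[C@@H]1CC(=O)c2sccc2[C@H]1c1ccc(OCC)cc1` carries an ethoxy group in place of the methoxy group, and in this assay compound 2 gives 17.1%; the step of a number 2.1 percentage points higher from compound 1 to compound 2 (within the scatter) is the only one-change step among the measured compounds. Compound 3 `CCOC(=O)[C@@H]1CC(=O)c2sccc2[C@H]1c1ccccc1OC` moves the methoxy group to a different position on the aromatic ring, and in this assay compound 3 gives 10.8%. On the numbers shown, compound 3 differs from compound 1 and from compound 2 by amounts that fall within the usual scatter, so none of the three is set apart from the others.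

Compound 4 `CCOC(=O)[C@@H]1CC(=O)c2sccc2[C@H]1c1ccc(OC)cc1OC` is not yet measured. It differs from compound 3 by methoxy in place of hydrogen on an aromatic carbon. Within the data shown here, no measured step adds a second methoxy group, so the only step that bears on it is the one from compound 1 to compound 2, which stayed within the scatter; there is no ground in these numbers for expecting a change beyond the scatter in this assay. The step of a number 2.2 percentage points higher from compound 3 to compound 4 (within the scatter) is therefore expected to be small. Compound 4 is estimated to give 13% in this assay, within a range from 4% to 24%.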

Compound 4, a percentage reported as activity, at one concentration (the size of the read-out at that concentration, not a potency): 9.76%
Compound 4: middle estimate off by 3.2 percentage points, on the high side, and the stated range covers the measured number.
By their numbers in this assay, from the lowest: compounds 4, 3, 1 and 2 (each within the scatter of the next).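

Compound 4 shows what a second methoxy group on the aromatic ring does in this assay: entering para to a large group and meta to a methoxy group, methoxy in place of hydrogen on an aromatic carbon gives a number 1 percentage points lower from compound 3 to compound 4 (within the scatter), and the same kind of change read from the other single-methoxy compound gives a number 5.2 percentage points lower from compound 1 to compound 4 (within the scatter). Both readings therefore agree that this addition does not set compound 4 apart from either compound with one methoxy group, so this position accepts the added methoxy group without a change that can be told from the scatter. No measurement is available that could explain this outcome.

The compounds shown leave open whether a different group at this place, such as an amine, a hydroxyl group or a carboxylic acid, would move the read-out beyond the scatter. They also leave open what the shared core does with no alkoxy group on its aromatic ring, and whether a longer chain, such as butoxy, would behave as the ethoxy group of compound 2 does.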